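A few compounds are considered here, and "the series" means these few. Any claim that something is new, unique, unknown or untested is made for them only; others in the source may bear on it.

Of the compounds shown here, two with the same bicyclic amide core have been measured in an assay on CHO cells for displacement of a labelled ligand from Neuronal acetylcholine receptor; alpha3/alpha6/beta2/beta3 (Homo sapiens), read by scintillation counting; on this read-out higher numbers stand for weaker inhibition and lower numbers for stronger inhibition. Compound 1 `CCC(=O)N1CC2CC(C1)N2` gives 190 nM in this assay. For the measured compounds named here, compound 2 `O=C([C@@H]1C[C@H]1F)N1CC2CC(C1)N2` gives 43 nM in this assay, and the step of a 4.4-fold lower number from compound 1 to compound 2 (0.65 log units; beyond the scatter) is the only comparison available so far. Compound 2 therefore stands at the lowest of the two numbers, with compound 1 the nearest neighbour at a higher number.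

Compound 3 `C[C@H]1C[C@@H]1C(=O)N1CC2CC(C1)N2` differs from compound 2 in a single place: 2-methylcyclopropyl in place of 2-fluorocyclopropyl on a carbonyl carbon. Going by the values given here, the only measured step, from compound 1 to compound 2, touches the same carbonyl carbon but swaps a chain for a ring, so it does not show what replacing the fluorine on that ring by a methyl does. Since the ring itself is kept, a smaller movement than the measured step is expected, most likely back toward the number of compound 1 in this assay, giving an expected 2.0-fold higher number from compound 2 to compound 3 (0.30 log units; within the scatter). The estimate for compound 3 in this assay is 85 nM, within a range from 30 nM to 250 nM.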

Compound 3, inhibition constant: 310 nM
Estimate against measurement, compound 3: 3.6-fold (0.56 log units) below; the whole stated range lies below it.
By their numbers in this assay, from the lowest: compound 2; then compounds 1 and 3 (each within the scatter of the next).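

The ring alone does not account for the lower number of compound 2: the 2-methylcyclopropyl group keeps the three-membered ring and the same count of heavy atoms, yet in this assay the swap gives a 7.2-fold higher number from compound 2 to compound 3 (0.86 log units; beyond the scatter). Set against the open ethyl group, the methyl-bearing ring gives a 1.6-fold higher number from compound 1 to compound 3 (0.21 log units; within the scatter), so on this carbonyl carbon the chain and the 2-methylcyclopropyl ring cannot be told apart, and among these three compounds only the 2-fluorocyclopropyl group stands out. This position therefore responds to a single change on the ring, fluorine to methyl, with a step larger than the usual scatter, but no measurement at hand gives a reason for that.

A plain cyclopropyl group, with hydrogen in place of the fluorine or methyl, would show whether the gap between compound 2 and compound 3 comes from fluorine lowering the number, from methyl raising it, or from both. A 2-fluoroethyl group on the same carbonyl carbon would show whether the fluorine goes with a lower number without the ring.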